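Swapping a Dimethoxyphenyl Ring for a Methylphenyl Ring

This account rests on a few compounds, and the source may have more. Where it says the series, first, only, none or still open, it means among the compounds named here.

Of the compounds shown here, three sharing one core have been tested in a functional assay on L1210 cells (Mus musculus) for antiproliferative activity; a lower number here means a stronger inhibitor, a higher number a weaker inhibitor. Compound 1 `COc1ccc(-c2cc(N)c(C(=O)c3cc(OC)c(OC)c(OC)c3)s2)cc1OC` gives 40 nM, the highest of the three numbers. Compound 2 `COc1cc(C(=O)c2sc(-c3ccsc3)cc2N)cc(OC)c1OC` gives 12 nM, and compound 3 `COc1cccc(-c2cc(N)c(C(=O)c3cc(OC)c(OC)c(OC)c3)s2)c1` gives 22 nM. Exchanging the whole aryl ring gave a 3.3-fold lower number from compound 1 to compound 2 (0.52 log units; beyond the scatter), whereas removing a single methoxy gave a 1.8-fold lower number from compound 1 to compound 3 (0.26 log units; within the scatter). Compound 4 `COc1cc(C(=O)c2sc(-c3ccc(C)cc3)cc2N)cc(OC)c1OC` is not yet measured; against compound 1 the change is 4-methylphenyl in place of 3,4-dimethoxyphenyl on an aromatic carbon. Both earlier steps bear on this: the ring exchange lowered the number modestly, while the loss of one methoxy stayed inside the scatter. A small to modest lowering in this assay is therefore expected for compound 4, roughly a 2.0-fold lower number from compound 1 to compound 4 (0.30 log units; within the scatter). Compound 4 is estimated at 20 nM, with a range from 8 nM to 50 nM.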

Compound 4, half-maximal inhibitory concentration: 18 nM
Estimate against measurement, compound 4: 1.1-fold (0.05 log units) above; low and high end bracket the measured number.
By their numbers in this assay, from the lowest: compounds 2, 4, 3 and 1 (each within the scatter of the next, the first and the last beyond it).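

In this assay, this position on the shared core also accepts 4-methylphenyl, a ring with no hydrogen-bond acceptors, giving a 2.2-fold lower number from compound 1 to compound 4 (0.35 log units; beyond the scatter) as a step beyond the scatter. The new ring cannot be told apart from the other two replacements, with a 1.2-fold lower number from compound 3 to compound 4 (0.09 log units; within the scatter) and a 1.5-fold higher number from compound 2 to compound 4 (0.18 log units; within the scatter) both within the scatter. Thiophen-3-yl, 3-methoxyphenyl and 4-methylphenyl therefore give numbers of one level here.

No evidence shown explains these numbers. Going by these compounds, how a phenyl ring bearing an amine or a carboxylic acid would behave at this position remains open.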